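Taking the Bromo Off Compound 3

The compounds below may be only part of what the source reports. "The series", "measured", "known", "first", "only" and "open" are said of these compounds alone.

Of the compounds shown here, three carrying a bromo group have been measured in a functional assay on A549 cells (Homo sapiens) for antiproliferative activity, read by MTT assay, with a stated time of 48 h; a higher number here means a weaker inhibitor, a lower number a stronger inhibitor. Compound 1 `COc1ccc(C(=O)Nc2nnc(/C=C/c3cc(OC)c(OC)c(OC)c3Br)s2)cc1` gives 150 nM, compound 2 `COc1cc(/C=C/c2nnc(NC(=O)c3cccc(Cl)c3)s2)c(Br)c(OC)c1OC` gives 70 nM, and compound 3 `COc1cc(/C=C/c2nnc(NC(=O)c3cccc(O)c3)s2)c(Br)c(OC)c1OC` gives 120 nM, a value within the scatter of both others. Compound 4 `COc1cc(/C=C/c2nnc(NC(=O)c3cccc(O)c3)s2)cc(OC)c1OC` differs from compound 3 in one place: hydrogen in place of bromo on an aromatic carbon. Among the measured compounds shown here, no measured step touches this bromo group. The available steps change only the aryl group on the carbonyl carbon: a 2.1-fold lower number from compound 1 to compound 2 (0.33 log units; beyond the scatter), a 1.3-fold lower number from compound 1 to compound 3 (0.10 log units; within the scatter) and a 1.7-fold higher number from compound 2 to compound 3 (0.23 log units; within the scatter). They show how far this small set moves, but they give no direction for the new change. The expected step is small, a 1.7-fold higher number from compound 3 to compound 4 (0.22 log units; within the scatter), and its direction is uncertain. Compound 4 is estimated at 200 nM, with an expected range from 60 nM to 700 nM.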

Compound 4, half-maximal inhibitory concentration: 190 nM
For compound 4 the middle estimate is 1.1-fold (0.02 log units) above the measured one; measured number inside the range.
By their numbers in this assay, from the lowest: compounds 2, 3, 1 and 4 (each within the scatter of the next, the first and the last beyond it).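

Among the compounds shown here, this is the first measured step at the bromo position itself: a 1.6-fold higher number from compound 3 to compound 4 (0.20 log units; within the scatter) in this assay. On the 3-hydroxyphenyl compounds, then, hydrogen can stand in place of bromo without a difference that this measurement can separate from scatter. Nothing shown here offers an explanation for this result.

As far as these compounds go, whether the same replacement would give a similar step alongside the 3-chlorophenyl group of compound 2 remains open. So does the outcome of placing a fluoro, a methyl or an amine at this position.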